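Turning one ring stereocentre in a hydroxymethyl diterpenoid

This account rests on a few compounds, and the source may have more. Where it says the series, first, only, none or still open, it means among the compounds named here.

The measured compounds in a functional assay on DU-145 cells (Homo sapiens) for cytotoxicity, read by MTT assay, with a stated time of 24 h; a higher number here means a weaker inhibitor, a lower number a stronger inhibitor:
Compound 1, `C=C1C(=O)[C@H]2C[C@]1(O)CC1=C2[C@]2(C)CCCC(C)(C)[C@H]2CC1`, gives 3200 nM.
Compound 2, `C[C@@H]1C(=O)[C@H]2C[C@]1(O)CC1=C2[C@]2(C)CCC[C@](C)(CO)[C@H]2CC1`, reaches only the limit > 50000 nM.
Compound 3, `C[C@@H]1C(=O)[C@H]2C[C@]1(O)CC1=C2[C@]2(C)CCC[C@](C)(C=O)[C@H]2CC1`, likewise reaches only the limit > 50000 nM.

Compound 2 therefore stands at a limit of this assay, not at a number, and it shares that position with compound 3, as the limit of > 50000 nM in this assay, at which 2 of the 3 values shown sit, records. For the measured compounds named here, the one single-point change among the measured compounds, formyl in place of hydroxymethyl on a saturated ring carbon, is a step that the two limits leave unreadable from compound 2 to compound 3, so it gives no readable size. Going by the values given here, compound 1, which lacks the hydroxymethyl and carries a different core, is the only compound with a number.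

Compound 4, `C[C@@H]1C(=O)[C@H]2C[C@]1(O)CC1=C2[C@]2(C)CCC[C@@](C)(CO)[C@H]2CC1`, is the subject of the next step. From compound 2 it changes as follows: the two compounds have the same atoms and bonds and differ only in configuration as drawn: 1 of 6 stereo elements differ; a stereocentre at a saturated ring carbon is drawn S in compound 2 and R in compound 4. Among the compounds with values here, no measured step shows how a change of configuration alone moves this assay, so the expectation rests mainly on the limit of compound 2. Compound 4 is expected to stay near that limit, estimated at 40000 nM with a range from 8000 nM to 100000 nM. The expected step is an at least 1.2-fold lower number from compound 2 to compound 4 (0.09 log units; that floor lies within the scatter), a movement that cannot be resolved against a limit.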

Compound 4, half-maximal inhibitory concentration: > 50000 nM
Compound 4: only a limit was reported; the forecaster's own chance of this, stated with the estimate: 60%; middle value at least 1.2-fold (0.09 log units) from the limit.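

In this assay, for the compounds shown here, compound 2 and compound 4 both stand at a limit, so the change of configuration between them gives no step that can be read: the limit of > 50000 nM in this assay, at which 3 of the 4 values shown sit. The compounds shown leave open whether the configuration at that saturated ring carbon moves the activity of these hydroxymethyl compounds at all.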